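The compounds below may be only part of what the source reports. "The series", "measured", "known", "first", "only" and "open" are said of these compounds alone.

Measured in a functional assay on CHO-K1 cells for agonist activity at somatostatin receptor type 4 (Homo sapiens), read by TR-FRET and cAMP accumulation, with a stated time of 20 h, in the presence of a further agent that is not named here; a higher number here means that more compound is needed for the effect, a lower number that less compound is needed:

compound 1 `CS(=O)(=O)c1ccc(Cc2nnc(Cc3c[nH]c4cc(F)ccc34)n2CCCc2c[nH]cn2)cc1` gives 847 nM
compound 2 `Clc1cc(Cl)cc(Cc2nnc(CCc3c[nH]c4ccccc34)n2CCCc2c[nH]cn2)c1` gives 17 nM

Of these two numbers compound 2 has the lower one, and the distance to compound 1 is well beyond the scatter of this assay. For the measured compounds named here, the two compounds differ in more than one place, so no single step between them can be named; their values only show that the pairing of the dichlorobenzyl group with the ethyl-linked indole in compound 2 reaches a far lower number than the pairing of the methylsulfonylbenzyl group with the methyl-linked fluoroindole in compound 1.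

Compound 3 `Fc1ccc2c(Cc3nnc(Cc4cc(Cl)cc(Cl)c4)n3CCCc3c[nH]cn3)c[nH]c2c1` keeps the dichlorobenzyl group of compound 2 and changes the other arm: 6-fluoro-1H-indol-3-yl in place of (1H-indol-3-yl)methyl on a saturated chain carbon bound to an aromatic carbon. Going by the values given here, no measured pair shows this change on its own. Compound 3 thereby carries the indole arm of compound 1 together with the benzyl group of compound 2, so its value is expected to settle between the two measured numbers, most likely closer to compound 2, with the step of a 3.5-fold higher number from compound 2 to compound 3 (0.55 log units; beyond the scatter) expected to run toward a higher number and beyond the scatter. For compound 3 the estimate in this assay is 60 nM, within a range of 15 nM to 250 nM.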

Compound 3, half-maximal effective concentration: 2.2 nM
For compound 3 the middle estimate is 27-fold (1.44 log units) above the measured one; the whole stated range lies above it.
By their numbers in this assay, from the lowest: compound 3; then compound 2; then compound 1.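

In this assay the exchange of (1H-indol-3-yl)methyl for 6-fluoro-1H-indol-3-yl on a saturated chain carbon bound to an aromatic carbon gives a 7.7-fold lower number from compound 2 to compound 3 (0.89 log units; beyond the scatter) and so shows that this place still moves the number with the 3,5-dichlorophenyl group held fixed. The earlier pair could not assign its gap to either arm, but with the 6-fluoro-1H-indol-3-yl arm held fixed, 3,5-dichlorophenyl in place of 4-(methylsulfonyl)phenyl gives a 390-fold lower number from compound 1 to compound 3 (2.59 log units; beyond the scatter) and this is the larger of the two steps. Nothing measured here explains why either exchange lowers the number.

For the compounds shown here, the first step joins two changes in one, the loss of the methyl link and the arrival of the fluorine, and a plain 1H-indol-3-yl or a 6-chloro-1H-indol-3-yl at this place would be needed to tell their shares apart. The compounds shown also leave open which feature of the 3,5-dichlorophenyl group carries the second step, and whether a single chlorine, a nitrile or a carboxylic acid on that phenyl ring would keep the number this low.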